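This account rests on a few compounds, and the source may have more. Where it says the series, first, only, none or still open, it means among the compounds named here.

In a functional assay on the whole organism for antagonist activity, with Mus musculus as the target, in the maximal electroshock model (on this read-out higher numbers stand for an effect only at larger amounts of compound and lower numbers for an effect already at smaller amounts), compound 1 (`COC(=O)NC1=NC(c2ccccc2)CN1C`) gives 107 mg/kg. Compound 2 (`CCN1CC(c2ccccc2)N=C1NC(=O)OC`) gives 66 mg/kg, and compound 3 (`COC(=O)NC1=NC(c2ccccc2F)CN1C`) gives 74 mg/kg. Both lie within the scatter of compound 1, which therefore holds no distinct place among the three.

Compound 4 (`COC(=O)NC1=NC(c2ccc(SC)cc2)CN1C`) has methylsulfanyl in place of hydrogen on an aromatic carbon, para to a large group: methylsulfanyl in place of hydrogen on an aromatic carbon.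

The closest measured precedent is a 1.4-fold lower number from compound 1 to compound 3 (0.16 log units; within the scatter), which also replaces hydrogen on an aromatic carbon, but with fluoro. The other measured step, a 1.6-fold lower number from compound 1 to compound 2 (0.21 log units; within the scatter), is made elsewhere in the molecule and bears on the change only loosely. Among the compounds with values here, both steps stay within the scatter, and no measured compound carries methylsulfanyl, so the precedent is thin.

No step beyond the scatter is expected in this assay, and any direction is tentative. The estimated change is a 1.3-fold lower number from compound 1 to compound 4 (0.10 log units; within the scatter). For compound 4 the estimated value is 85 mg/kg, with an expected range from 38 mg/kg to 190 mg/kg.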

Compound 4, dose for half-maximal effect: 100 mg/kg
Estimate against measurement, compound 4: 1.2-fold (0.07 log units) below; the measured number falls inside the stated range.
By their numbers in this assay, from the lowest: compounds 2, 3, 4 and 1 (each within the scatter of the next).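

Among the compounds shown, only compound 4 carries a group at this place, para to a large group, and methylsulfanyl there gives a 1.1-fold lower number from compound 1 to compound 4 (0.03 log units; within the scatter) in this assay. A substituent of 2 heavy atoms, 1 of them sulfur, therefore leaves the number within the scatter of compound 1 at this place. With a 1.4-fold lower number from compound 1 to compound 3 (0.16 log units; within the scatter), two different replacements of hydrogen on an aromatic carbon now stay within the scatter, a pattern resting on compound 3 and compound 4 alone, with no compound shown against it. Nothing available explains this outcome at the level of the group or the position.

On these data alone, whether a primary amine, a carboxylic acid or a longer chain such as butylsulfanyl at this place would give a step beyond the scatter remains open. Also open, as far as these compounds go, is whether methylsulfanyl would behave the same on the core of compound 2, which carries the ethyl group on the ring nitrogen.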